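The compounds below may be only part of what the source reports. "The series", "measured", "known", "first", "only" and "open" are said of these compounds alone.

Working notes on the series.

Of the compounds shown here, two have been measured in an assay on isolated protein for inhibition of Amine oxidase [flavin-containing] B (Homo sapiens), read by fluorescence, with a stated time of 1 h; a higher number here means a weaker inhibitor, a lower number a stronger inhibitor. Compound 1 `Clc1cccc(-c2nc3ccc(N4CCCCC4)nc3o2)c1` gives 335 nM. Compound 2 `c1ccc(-c2nc3ccc(N4CCCCC4)nc3s2)cc1` gives 356 nM in this assay; this is the higher of the two numbers, but the two values lie within the scatter of each other, so nothing can be read from their order. Within the data shown here, compound 1 and compound 2 differ in more than one place, and no single step between them is available; the two values simply show that both sit at a similar level.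

Compound 3 `Clc1ccccc1-c1nc2ccc(N3CCCCC3)nc2s1` has not yet been measured. It differs from compound 2 by chloro in place of hydrogen on an aromatic carbon. Among the measured compounds shown here, no measured pair in the set isolates this change, so its size is unknown here. For the measured compounds named here, with the only anchor being compound 2 at 356 nM, a small step is expected, most likely none beyond the scatter and, if anything, toward a slightly higher number, as a 1.2-fold higher number from compound 2 to compound 3 (0.07 log units; within the scatter). Compound 3 is therefore estimated at 420 nM in this assay, with a range from 150 nM to 1200 nM.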

Compound 3, half-maximal inhibitory concentration: 171 nM
Compound 3: middle estimate off by 2.5-fold (0.39 log units), on the high side; measured number inside the range.
By their numbers in this assay, from the lowest: compounds 3, 1 and 2 (each within the scatter of the next, the first and the last beyond it).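

Among these compounds, the phenyl to 2-chlorophenyl change, with chloro ortho to a large group on the six-membered aromatic ring, gives the first single-change reading: in this assay it produces a 2.1-fold lower number from compound 2 to compound 3 (0.32 log units; beyond the scatter) as a modest step. This position on the ring therefore responds to substitution, and one chlorine atom in place of hydrogen moves the number toward a stronger inhibitor, whereas compound 1 and compound 2 differ in more than one place and showed only that both sit at a similar level. No measurement at hand accounts for the step, which stands here as an observation only.

As far as these compounds go, it remains open whether the step belongs to chlorine itself or to this place on the ring, a question that a fluoro or methyl group at the same place, or chloro elsewhere on the same ring, would address. Also open, from the compounds shown here alone, is whether the step carries over to the core of compound 1, and whether a methoxy group or an amine at this place would read as chloro does in this assay in the same direction.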